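A Larger Side Chain on the Shared Core

A few compounds are considered here, and "the series" means these few. Any claim that something is new, unique, unknown or untested is made for them only; others in the source may bear on it.

For the measured compounds named here, compound 1 `CCNc1cc(-c2ccc(NC(=O)Nc3cccc(Cl)c3)cc2C(F)(F)F)ccn1` gives the lower of the two numbers so far in a functional assay on MCF7 cells (Homo sapiens) for cytotoxicity, read by MTT assay, with a stated time of 24 h (a lower number here means a stronger inhibitor, a higher number a weaker inhibitor), where compound 1 gives 1240 nM. Compound 2 `CCNc1cc(-c2ccc(NC(=O)Nc3ccc(OC)cc3)cc2C(F)(F)F)ccn1` gives 5740 nM, a step of a 4.6-fold higher number from compound 1 to compound 2 (0.67 log units; beyond the scatter) that swaps the group on the amide-type nitrogen. Compound 3 `O=C(Nc1cccc(Cl)c1)Nc1ccc(-c2ccnc(NCC3CC3)c2)c(C(F)(F)F)c1` instead differs from compound 1 elsewhere: cyclopropyl in place of methyl on a saturated chain carbon bound to a nitrogen on an aromatic ring. Going by the values given here, the single measured step changes a different part of the shared core, so it offers no direct guide here; with nothing pulling the number either way, the step is expected to stay within the scatter, a 1.1-fold lower number from compound 1 to compound 3 (0.05 log units; within the scatter). Compound 3 is therefore expected to give 1100 nM, between 400 nM and 3000 nM.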

Compound 3, half-maximal inhibitory concentration: 17400 nM
Estimate against measurement, compound 3: 16-fold (1.20 log units) below, and the stated range ends below it.
By their numbers in this assay, from the lowest: compound 1; then compound 2; then compound 3.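

Compound 1's ethylamino group is not a neutral place to make changes: replacing ethyl with cyclopropylmethyl gives a 14-fold higher number from compound 1 to compound 3 (1.15 log units; beyond the scatter) in this assay. A change of only a few carbon atoms at this position, far from the amide-type nitrogen, is therefore enough to weaken the compound markedly. Nothing measured here accounts for this step.

With only this one replacement shown, it remains open whether the higher number goes with the cyclopropyl ring or simply with the added carbons. A straight propyl chain in the same place would help separate the two.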